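A few compounds are considered here, and "the series" means these few. Any claim that something is new, unique, unknown or untested is made for them only; others in the source may bear on it.

Measured compounds:
Compound 1 `NC1(CCn2ncc(=O)[nH]c2=O)OC(=O)C(OCc2ccccc2)=C1OCc1ccccc1` — in a functional assay on HepG2 cells (Homo sapiens) for inhibition, read by MTT assay, with a stated time of 72 h (on this read-out lower numbers stand for stronger inhibition and higher numbers for weaker inhibition), compound 1 gives a limit of > 100000 nM.
Compound 2 `NC1(CCn2cc(F)c(=O)[nH]c2=O)OC(=O)C(OCc2ccccc2)=C1OCc1ccccc1` — in this assay compound 2 gives 42800 nM.
Compound 3 `Nc1ccn(CCC2(N)OC(=O)C(OCc3ccccc3)=C2OCc2ccccc2)c(=O)n1` — in this assay compound 3 gives a limit of > 100000 nM.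

Compound 3 thus stands at the limit, and the limit of > 100000 nM in this assay, at which 2 of the 3 values shown sit, shows how common that position is in this set. Compound 4 `Cc1cn(CCC2(N)OC(=O)C(OCc3ccccc3)=C2OCc2ccccc2)c(=O)[nH]c1=O` differs from compound 3 by a group of 9 heavy atoms (5 carbon, 2 nitrogen, 2 oxygen; one six-membered aromatic ring with 2 hetero atoms) in place of a group of 8 heavy atoms (4 carbon, 3 nitrogen, 1 oxygen; one six-membered aromatic ring with 2 hetero atoms), on a saturated chain carbon, two bonds along the chain from a saturated ring carbon. Among the compounds with values here, the steps that bear on this change are an at least 2.3-fold higher number from compound 2 to compound 3 (0.36 log units; beyond the scatter) and a step that the two limits leave unreadable from compound 1 to compound 3; only compound 2 gives a number, and even that is a weak one. Exchanging the group at this place has so far produced at most a modest step, so compound 4 is expected to show an at least 1.1-fold lower number from compound 3 to compound 4 (0.04 log units; that floor lies within the scatter), that is no change beyond the scatter. Compound 4 is estimated at 90000 nM, with a range from 30000 nM to 300000 nM.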

Compound 4, half-maximal inhibitory concentration: > 100000 nM
Compound 4: no number, only a limit; the forecaster's own chance of this, stated with the estimate: 55%; at least 1.1-fold (0.04 log units) between middle value and limit.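

Methyl in place of fluoro on an aromatic carbon gives an at least 2.3-fold higher number from compound 2 to compound 4 (0.36 log units; beyond the scatter), so among the compounds shown only the fluoro group of compound 2 yields a number at this place. Compound 4 gives only a limit, and its steps from compound 1 and compound 3 cannot be read. Most of the set now sits at one end of the scale: the limit of > 100000 nM in this assay, at which 3 of the 4 values shown sit.

On these data alone, what chloro on that aromatic carbon would give remains open. So does the effect of a longer chain in place of the present one, on the fluoro compound in particular.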